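Naphthyl replacement on the biaryl isatin scaffold

A few compounds are considered here, and "the series" means these few. Any claim that something is new, unique, unknown or untested is made for them only; others in the source may bear on it.

Compound 1 `COc1ccc(CN2C(=O)C(=O)c3cc(-c4ccc(C)cc4)ccc32)cc1` carries a 4-methylphenyl group on the shared core; in a functional assay on K562 cells (Homo sapiens) for antiproliferative activity, read by MTT assay, with a stated time of 48 h (on this read-out higher numbers stand for weaker inhibition and lower numbers for stronger inhibition), compound 1 gives 400 nM. Compound 2 `COc1ccc(CN2C(=O)C(=O)c3cc(-c4ccc(OC(C)C)cc4)ccc32)cc1` differs only by isopropoxy in place of methyl on an aromatic carbon, and in this assay compound 2 gives 310 nM. The step of a 1.3-fold lower number from compound 1 to compound 2 (0.11 log units; within the scatter) leaves the two compounds within the scatter of each other, so compound 2 stands level with compound 1 on the numbers shown.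

Compound 3 `COc1ccc(CN2C(=O)C(=O)c3cc(-c4ccc5ccccc5c4)ccc32)cc1` makes a larger change at the same position: naphthalen-2-yl in place of 4-isopropoxyphenyl on an aromatic carbon. Going by the values given here, only the step from compound 1 to compound 2 bears on this position, and it was within the scatter, so no measured step speaks for a move beyond the scatter in this assay. Compound 3 is therefore expected to land near compound 2, with an estimated step of a 1.1-fold higher number from compound 2 to compound 3 (0.05 log units; within the scatter). The estimate for compound 3 in this assay is 350 nM, within a range from 140 nM to 900 nM.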

Compound 3, half-maximal inhibitory concentration: 340 nM
Estimate against measurement, compound 3: 1.0-fold (0.01 log units) above, and the stated range covers the measured number.
By their numbers in this assay, from the lowest: compounds 2, 3 and 1 (each within the scatter of the next).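

In this assay, the exchange of the 4-isopropoxyphenyl group for naphthalen-2-yl gives a 1.1-fold higher number from compound 2 to compound 3 (0.04 log units; within the scatter), and the exchange of the 4-methylphenyl group for the same fused group gives a 1.2-fold lower number from compound 1 to compound 3 (0.07 log units; within the scatter). The earlier step changed only the substituent on a single ring, whereas these steps show that a second fused aromatic ring, with no oxygen in the group, also leaves the number within the scatter, so all three compounds stand level at this position. Nothing available gives a reason for this flat result.

All three groups shown are aromatic and carry no net charge. From the compounds shown here alone, how a ring bearing an amine or a carboxylic acid would read in this assay remains open, as does whether any such group would move the number beyond the scatter.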